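Hydrazone substituent changes on the shared adenosine core

The source may report more compounds than this note shows. Statements on the series, on what has been measured and on what is new or still open speak of the compounds shown alone.

Measured compounds in an assay on CHO-K1 cells for displacement of a labelled ligand from adenosine receptor A1 (Homo sapiens), read by scintillation counting, with a stated time of 60 min; on this read-out lower numbers stand for stronger inhibition and higher numbers for weaker inhibition:
Compound 1, `Nc1nc(N/N=C/c2cncs2)nc2c1ncn2[C@@H]1O[C@H](CO)[C@@H](O)[C@H]1O`, gives 22 nM.
Compound 2, `CCCOc1ccc(/C=N/Nc2nc(N)c3ncn([C@@H]4O[C@H](CO)[C@@H](O)[C@H]4O)c3n2)cc1`, sits at the assay limit of > 10000 nM.
Compound 3, `Nc1nc(N/N=C/C2CCCC2)nc2c1ncn2[C@@H]1O[C@H](CO)[C@@H](O)[C@H]1O`, gives 5.6 nM.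

Among the measured compounds shown here, compound 3 stands lowest of the two numbers recorded; the only other number belongs to compound 1, and the step of a 3.9-fold lower number from compound 1 to compound 3 (0.59 log units; beyond the scatter) lies beyond the scatter. The remaining value is a limit, as noted in the limit of > 10000 nM in this assay, at which 1 of the 3 values shown sits.

Compound 4, `N#Cc1ccc(/C=N/Nc2nc(N)c3ncn([C@@H]4O[C@H](CO)[C@@H](O)[C@H]4O)c3n2)cc1`, differs from compound 3 in one place: 4-cyanophenyl in place of cyclopentyl on a carbon with a double bond to nitrogen. For the measured compounds named here, three measured steps bear on this change. Replacing the five-membered aromatic ring of compound 1 with a six-membered aromatic ring carrying a para substituent gave an at least 450-fold higher number from compound 1 to compound 2 (2.65 log units; beyond the scatter). The comparison to the cyclopentyl analogue is even larger: an at least 1700-fold lower number from compound 2 to compound 3 (3.25 log units; beyond the scatter). Both steps point the same way: moving from a non-aromatic five-membered carbon ring to a substituted six-membered aromatic ring on the carbon with a double bond to nitrogen raises the number sharply. The 4-cyanophenyl group of compound 4 is not identical to the 4-propoxyphenyl of compound 2, so the magnitude is uncertain, but a large rise in this assay is expected.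

Compound 4 is therefore expected to give about 1500 nM, estimated within 150 nM to 10000 nM. The expected step from compound 3 is a 270-fold higher number from compound 3 to compound 4 (2.43 log units; beyond the scatter), with a real chance that only a limit is returned.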

Compound 4, inhibition constant: 4.1 nM
The estimate for compound 4 lay 370-fold (2.56 log units) above the measured number, and the stated range ends above it.
By their numbers in this assay, from the lowest: compounds 4 and 3 (each within the scatter of the next); then compound 1. At a limit, above all of these: compound 2.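

In this assay, a substituted six-membered aromatic ring on the carbon with a double bond to nitrogen is compatible with a low number: 4-cyanophenyl and cyclopentyl cannot be told apart (a 1.4-fold lower number from compound 3 to compound 4 (0.14 log units; within the scatter)), and 4-cyanophenyl also stands clear of 1,3-thiazol-5-yl (a 5.4-fold lower number from compound 1 to compound 4 (0.73 log units; beyond the scatter)). The sharp rise seen with compound 2 therefore cannot be read as belonging to the aromatic ring as such, since the two aromatic compounds differ only in the group on that ring, with cyano in place of propoxy (an at least 2400-fold lower number from compound 2 to compound 4 (3.38 log units; beyond the scatter)). That step has a floor and not an exact size, as compound 2 gives no number, only a limit: the limit of > 10000 nM in this assay, at which 1 of the 4 values shown sits.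

As far as these compounds go, only cyano and propoxy are compared on this ring, so it stays open whether a methoxy, a hydroxyl or an amine in the same place would track the result of compound 4 or that of compound 2. Also open, from the compounds shown here alone, is whether a cyclohexyl or a benzyl group on the carbon with a double bond to nitrogen would give a number in the range of compound 3 and compound 4.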